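Amide nitrogen substitution: from compound 2 to compound 4

The compounds below may be only part of what the source reports. "The series", "measured", "known", "first", "only" and "open" are said of these compounds alone.

Measured so far:
compound 1 `NC(=O)/C=C1\CCc2c(F)cc(F)cc21` — 67%
compound 2 `O=C(/C=C1\CCc2ccc(F)cc21)NC1CCCC1` — 0%
compound 3 `O=C(/C=C1/CCc2ccc(Cl)cc21)NC1CC1` — 0%

In a functional assay on the whole organism with Mus musculus as the target, at a dose of 100 mg/kg by the intraperitoneal route (a lower number here means less inhibition, a higher number more inhibition at the dose given (going by the name of the read-out)), compound 1 gives 67%. Compound 2 gives 0% in this assay, and compound 3 gives 0%. Compound 2 and compound 3 are level at the digits shown and stand together at the bottom of the three numbers; the gap from compound 2 up to compound 1 lies well beyond the scatter. Among the compounds with values here, both compounds carrying a substituent on the amide-type nitrogen, compound 2 and compound 3, sit at the floor of the read-out, while the one compound without such a substituent, compound 1, is the only one with a clear signal; three compounds are too few to call this a pattern.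

Compound 4 `O=C(/C=C1\CCc2ccc(F)cc21)NCc1ccccc1` differs from compound 2 in one place: benzyl in place of cyclopentyl on an amide-type nitrogen. Within the data shown here, no step between measured compounds covers this change. Since compound 2 gives 0% and compound 3 with another substituent on the same nitrogen also shows nothing, compound 4 is expected to remain low, with the step of a number 10 percentage points higher from compound 2 to compound 4 (within the scatter) expected to stay within the scatter or rise only slightly. The estimate for compound 4 in this assay is 10%, with a range from 0% to 40%.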

Compound 4, a percentage reported as inhibition, in the whole organism at one dose (the size of the read-out at that dose, not a potency): 17%
Estimate against measurement, compound 4: 7 percentage points below; the measured number falls inside the stated range.
By their numbers in this assay, from the lowest: compounds 2 and 3 (each within the scatter of the next); then compound 4; then compound 1.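

On an amide-type nitrogen, benzyl in place of cyclopentyl gives a modest rise in this assay and reads as a number 17 percentage points higher from compound 2 to compound 4 (beyond the scatter) in the series notes. Within the data shown here, this is the first single-place comparison, and it shows that a substituted nitrogen need not sit at the floor of the read-out. The step alone shows only that the read-out responds to this exchange, and no evidence at hand bears on its origin.

Open, going by these compounds, is whether the rise follows the aromatic ring or the larger group, a question that phenyl or cyclohexyl on the same nitrogen would address. Also open, on these data alone, is how a longer chain such as phenethyl, or a chain ending in an amine, would read at this position.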